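This account rests on a few compounds, and the source may have more. Where it says the series, first, only, none or still open, it means among the compounds named here.

Compound 3 `CN(C)c1ccc(C2CC(c3ccc(-n4cncn4)cc3)=NN2C(=O)CCCl)cc1` was tested in a functional assay on NCI-H1975 cells (Homo sapiens) for inhibition, read by sulforhodamine B assay, tested at 10 uM (on this read-out lower numbers stand for less inhibition and higher numbers for more inhibition at the one concentration tested (going by the name of the read-out)), where compound 3 gives -0.7%. That is the lowest of the three numbers recorded, but only just against compound 1 `CN1CCN(c2ccc(C3=NN(C(=O)CCCl)C(c4ccc(N(C)C)cc4)C3)cc2)CC1`, which gives -0.2%; the step of a number 0.5 percentage points lower from compound 1 to compound 3 (within the scatter) lies within the scatter, so the two compounds cannot be told apart. Compound 2 `CN1CCN(c2ccc(C3=NN(S(=O)(=O)c4ccc(OC(F)(F)F)cc4)C(c4ccc(N(C)C)cc4)C3)cc2)CC1` gives 26.5%, a number well above the other two.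

Compound 4 `CN(C)c1ccc(C2CC(c3ccc(-n4cncn4)cc3)=NN2C(=O)/C=C/c2ccccc2)cc1` differs from compound 3 in one place: 2-phenylethenyl in place of 2-chloroethyl on a carbonyl carbon. Among the compounds with values here, no measured step covers this position. Within the data shown here, the one step measured, between compound 1 and compound 3, concerns a group on an aromatic carbon and shows no shift beyond the scatter. Compound 1 and compound 2 carry different groups attached to the amide-type nitrogen in a ring, and the higher number of compound 2 shows that a change at that part of the molecule can raise inhibition, though what the cinnamoyl-type change in compound 4 will do is not settled by these data. A modest rise is therefore expected rather than a fall. Compound 4 is estimated to give 15%, within a range of -5% to 40%. This estimate implies a step of a number 15.7 percentage points higher from compound 3 to compound 4 (beyond the scatter).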

Compound 4, a percentage reported as inhibition, at one concentration (the size of the read-out at that concentration, not a potency): -2.3%
The estimate for compound 4 lay 17.3 percentage points above the measured number, and the stated range covers the measured number.
By their numbers in this assay, from the lowest: compounds 4, 3 and 1 (each within the scatter of the next); then compound 2.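

In this assay, putting 2-phenylethenyl in place of 2-chloroethyl on a carbonyl carbon gives a number 1.6 percentage points lower from compound 3 to compound 4 (within the scatter) and is the first change shown at this position. The entering group is much larger than the one it replaces, bringing a six-membered aromatic ring and a double bond outside aromatic rings, yet the two compounds cannot be told apart at the one concentration tested. Swapping this one group on the carbonyl carbon, with the 1H-1,2,4-triazol-1-yl group kept in place, therefore does not by itself bring out inhibition, and no measurement available here offers an explanation for the lack of a shift.

As far as these compounds go, two groups at one position are a thin basis, so it remains open whether a different kind of group on the carbonyl carbon, such as a chain ending in an amine or a carboxylic acid, would move the number beyond the scatter. From the compounds shown here alone, it is also open whether 2-phenylethenyl would behave the same way in a compound carrying 4-methylpiperazin-1-yl on the aromatic carbon instead of the 1H-1,2,4-triazol-1-yl group.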